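This account rests on a few compounds, and the source may have more. Where it says the series, first, only, none or still open, it means among the compounds named here.

Measured compounds:
Compound 1, `COc1cccc(/C=C/C(=O)c2ccncc2)c1`: 620 nM
Compound 2, `CCOc1c(OC)cc(/C=C/C(=O)c2ccncc2)cc1OC`: 280 nM

Of the compounds shown here, two have been measured in an assay on HEK293 cells for inhibition of cytochrome P450 1A1 (Homo sapiens), read by fluorescence, with stated times of 30 min and 60 min; a lower number here means a stronger inhibitor, a higher number a weaker inhibitor. Compound 1 gives 620 nM, and compound 2 gives 280 nM. Of the two numbers, that of compound 2 is the lowest; its nearest neighbour is compound 1, whose number is higher by a margin beyond the usual scatter, so on this pair compound 2 is the stronger inhibitor.

The step under consideration leads from compound 2 to compound 3, `COc1cc(/C=C/C(=O)c2ccncc2)cc(OC)c1`. The change is hydrogen in place of ethoxy on an aromatic carbon; the hydrogen sits ortho to two methoxy groups and para to a large group. For the measured compounds named here, no step between measured compounds tells what this change does, and the two compounds measured so far differ in more than one place, so the expectation rests on little. A modest rise in the number, possibly within the scatter, is expected: a 1.5-fold higher number from compound 2 to compound 3 (0.18 log units; within the scatter). Compound 3 is estimated at 420 nM, with a range from 150 nM to 1100 nM.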

Compound 3, half-maximal inhibitory concentration: 220 nM
For compound 3 the middle estimate is 1.9-fold (0.28 log units) above the measured one, and the stated range covers the measured number.
By their numbers in this assay, from the lowest: compounds 3 and 2 (each within the scatter of the next); then compound 1.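

Hydrogen in place of ethoxy on the aromatic carbon ortho to two methoxy groups gives [ a 1.3-fold lower number from compound 2 to compound 3 (0.10 log units; within the scatter) ] in this assay, so the ethoxy group can be lost from this position with no change that stands clear of the scatter. For the compounds shown here, compound 3 also supplies the first comparison of compounds differing in one place that goes beyond the scatter: methoxy in place of hydrogen on an aromatic carbon gives [ a 2.8-fold lower number from compound 1 to compound 3 (0.45 log units; beyond the scatter) ], a modest strengthening of inhibition. No measurement available here explains either step.

The compounds shown leave open whether a methoxy group, an amine or a carboxylic acid on the carbon that held the ethoxy would move the number beyond the scatter. They also leave open whether a longer chain there would be accommodated as the ethoxy group is.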